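Heteroarylmethyl variation on the shared core: compound 4

A few compounds are considered here, and "the series" means these few. Any claim that something is new, unique, unknown or untested is made for them only; others in the source may bear on it.

Measured so far in an assay on isolated protein for displacement of a labelled ligand from Gonadotropin-releasing hormone receptor (Homo sapiens); on this read-out higher numbers stand for weaker inhibition and lower numbers for stronger inhibition:
compound 1 `Cn1cnc(CN2CCN(c3cccc4[nH]c(-c5ccc(C(C)(C)C)cc5)nc34)CC2)c1`; compound 1 gives 33 nM
compound 2 `Cc1nc(CN2CCN(c3cccc4[nH]c(-c5ccc(C(C)(C)C)cc5)nc34)CC2)c(C)s1`; compound 2 gives 21 nM
compound 3 `CCCn1cnc(CN2CCN(c3cccc4[nH]c(-c5ccc(C(C)(C)C)cc5)nc34)CC2)c1C`; compound 3 gives 12 nM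

Compound 3 holds the lowest of the three numbers. Against compound 1 the gap is a 2.8-fold lower number from compound 1 to compound 3 (0.44 log units; beyond the scatter), a modest but real difference; against compound 2 it is a 1.8-fold lower number from compound 2 to compound 3 (0.24 log units; within the scatter), so compounds 2 and 3 cannot be separated. The ring swap a 1.6-fold lower number from compound 1 to compound 2 (0.20 log units; within the scatter) likewise stays within scatter.

Compound 4 `CCCCc1nc(CN2CCN(c3cccc4[nH]c(-c5ccc(C(C)(C)C)cc5)nc34)CC2)cn1C` differs from compound 3 by 2-butyl-1-methyl-1H-imidazol-4-yl in place of 5-methyl-1-propyl-1H-imidazol-4-yl on a saturated chain carbon bound to an amine nitrogen in a ring. For the measured compounds named here, no measured step tests this exact change. Going by the values given here, the only step that touches the substituents on the imidazole is the one from compound 1 to compound 3, where the 5-methyl-1-propyl pattern in place of 1-methyl gave the modest gain already noted. Compound 4 retains the 1-methyl of compound 1 and carries a 2-butyl chain instead, with no information on whether that pattern repeats the gain seen for compound 3 or falls back toward compound 1.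

For compound 4 the expected step in this assay is a 1.5-fold higher number from compound 3 to compound 4 (0.18 log units; within the scatter), that is, nothing clearly beyond scatter, with a slight lean toward a higher number. Compound 4 is therefore estimated at 18 nM, within a range of 7 nM to 45 nM.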

Compound 4, half-maximal inhibitory concentration: 26 nM
Compound 4: middle estimate off by 1.4-fold (0.16 log units), on the low side; measured number inside the range.
By their numbers in this assay, from the lowest: compounds 3, 2, 4 and 1 (each within the scatter of the next, the first and the last beyond it).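

In this assay, adding the butyl to the 1-methyl-substituted imidazole gives a 1.3-fold lower number from compound 1 to compound 4 (0.10 log units; within the scatter), so this chain alone yields no change that can be told from scatter, whereas moving to the 2-butyl-1-methyl pattern from the 5-methyl-1-propyl pattern gives a 2.2-fold higher number from compound 3 to compound 4 (0.34 log units; beyond the scatter), a modest step beyond the scatter that shows the arrangement of alkyl groups on the imidazole can matter at this position, even with the ring itself unchanged. The 2-butyl-1-methyl-1H-imidazol-4-yl group also cannot be separated from the thiazole group, with a 1.2-fold higher number from compound 2 to compound 4 (0.09 log units; within the scatter), so the ring swap alone shows no clear effect in this comparison. No supporting measurement bears on the origin of the difference between the two imidazole patterns.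

The compounds shown leave open whether the gain of the 5-methyl-1-propyl pattern belongs to the propyl, the methyl or the two together, since both differ from the 1-methyl group at once. Also open, from the compounds shown here alone, is how a propyl chain, a longer chain or an amine carried on the butyl chain would behave in place of the 2-butyl group.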